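The source may report more compounds than this note shows. Statements on the series, on what has been measured and on what is new or still open speak of the compounds shown alone.

Compound 1 `ClCc1ccccc1Cn1cnc2c(Cl)nc(Cl)nc21` gives 6450 nM in a functional assay on OVCAR-8 cells (Homo sapiens) for cytotoxicity, read by sulforhodamine B assay, with a stated time of 48 h; a higher number here means that more compound is tolerated, a lower number that less compound is tolerated. Compound 2 `ClCc1cccc(Cn2cnc3c(Cl)nc(Cl)nc32)c1` gives 67600 nM in this assay. Compound 3 `Nc1nc(Cl)c2ncn(Cc3ccccc3CCl)c2n1` reaches only > 100000 nM in this assay, which is a limit of the assay and not a number.

Compound 3 differs from compound 1 by amino in place of chloro on an aromatic carbon, and the resulting step, an at least 15-fold higher number from compound 1 to compound 3 (1.19 log units; beyond the scatter), has its size set by the limit of > 100000 nM in this assay, at which 1 of the 3 values shown sits. Compound 2 shares its atoms with compound 1 joined differently; the difference between the two cores is not broken down here. In this assay compound 2 stands highest of the two numbers.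

Compound 4 `Nc1nc(Cl)c2ncn(Cc3cccc(CCl)c3)c2n1` is the unmeasured partner of compound 2, with amino in place of chloro on an aromatic carbon — the same change at the same place. Given an at least 15-fold higher number from compound 1 to compound 3 (1.19 log units; beyond the scatter) and the starting point of compound 2 at 67600 nM, compound 4 is expected to show a 5.9-fold higher number from compound 2 to compound 4 (0.77 log units; beyond the scatter). Compound 4 is thus expected around 400000 nM, most likely reported only as a limit.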

Compound 4, concentration lethal to 50% of the cells: 53700 nM
For compound 4 the middle estimate is 7.4-fold (0.87 log units) above the measured one; measured number outside the range, below it.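

Amino in place of chloro on an aromatic carbon does not carry a fixed step from one core to the other in this assay, where the new pair reads a 1.3-fold lower number from compound 2 to compound 4 (0.10 log units; within the scatter). The two steps on the two cores differ: the same change on two cores in this assay, an at least 15-fold higher number (1.19 log units; beyond the scatter) from compound 1 to compound 3 and a 1.3-fold lower number (0.10 log units; within the scatter) from compound 2 to compound 4, at least 19-fold (1.29 log units) apart, beyond the scatter of two such steps. The size of this gap rests on compound 3, whose value is a limit of the assay and not a number, and two pairs do not show which feature of the cores sets the steps apart: the limit of > 100000 nM in this assay, at which 1 of the 4 values shown sits.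

The compounds shown leave open how either core would respond to a methoxy group or a dimethylamino group in that same place. They also leave open whether a third core would follow compound 1 or compound 2.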